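Fluoro on compound 2: an expected half-life

The compounds below may be only part of what the source reports. "The series", "measured", "known", "first", "only" and "open" are said of these compounds alone.

Measured so far in an ADME assay on microsomes from liver (Homo sapiens) for metabolic stability, using NADPH, with a stated time of 40 min, tested at 2 uM; on this read-out higher numbers stand for a longer-lived compound and lower numbers for a shorter-lived compound:
- compound 1 `Fc1ccc2c(-c3ccc4ccccc4n3)c[nH]c2c1Cl` with 0.183 h 
- compound 2 `Cc1cccc2c(-c3ccc4ccccc4n3)c[nH]c12` with 0.35 h 

Among the compounds with values here, compound 2, at 0.35 h in this assay and thus one of only two numbers available, stands level with compound 1 within the usual scatter, so the two values do not separate them. Within the data shown here, these two compounds differ in more than one place, and no measured step isolates a single change.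

Compound 3 `Cc1c(F)ccc2c(-c3ccc4ccccc4n3)c[nH]c12` follows from compound 2 by one change: fluoro in place of hydrogen on an aromatic carbon on an aromatic carbon, ortho to a methyl group. Compound 3 thus keeps the methyl group of compound 2 and gains a fluoro group, which compound 1 also carries. Compound 1 at 0.183 h remains within the scatter of compound 2, and on that ground no step beyond the scatter is expected, at most a slight drift toward a shorter half-life. The estimate amounts to a 1.3-fold lower number from compound 2 to compound 3 (0.10 log units; within the scatter) and is expected to stay within the scatter. For compound 3 the expected half-life is 0.28 h with an estimated range from 0.14 h to 0.55 h as its bounds.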

Compound 3, half-life: 0.433 h
Beside the measured number, compound 3's estimate is 1.5-fold (0.19 log units) below it, within the range that was stated.
By their numbers in this assay, from the lowest: compounds 1, 2 and 3 (each within the scatter of the next, the first and the last beyond it).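

In this assay, fluoro in place of hydrogen on an aromatic carbon, ortho to a methyl group, gives a 1.2-fold higher number from compound 2 to compound 3 (0.09 log units; within the scatter), so at this position the fluoro group leaves the half-life indistinguishable from that of the parent within the usual scatter. With the fluoro group kept, methyl in place of chloro on an aromatic carbon gives a 2.4-fold higher number from compound 1 to compound 3 (0.37 log units; beyond the scatter), a modest step and the only single-place change among these compounds that lies beyond the scatter, which draws attention to the carbon carrying chloro in compound 1 and methyl in compound 3 rather than to the fluoro position. Nothing available accounts for either step.

Going by these compounds, it remains open whether a larger or differently built group at the fluoro position, such as a methoxy group, a nitrile or an amine, would also stay within the scatter of compound 2. On these data alone, it is equally open whether methyl in place of chloro would give a similar step without the fluoro group, or whether an ethyl group or a trifluoromethyl group on that carbon would extend it.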